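A Fluoro Swap Among Three Limits

The source may hold more compounds than are shown below. What is called first, only, known or untested is meant among the compounds shown, and "the series" means these compounds.

In an ADME assay on HepG2 cells (Homo sapiens) for cytotoxicity, with a stated time of 72 h (on this read-out higher numbers stand for an effect only at larger amounts of compound and lower numbers for an effect already at smaller amounts), compound 3 (`Cc1ccc(-c2nc3ccccc3s2)cc1NC(=O)c1cc([N+](=O)[O-])ccc1Cl`) gives > 14000 nM as a limit. Compound 1 (`O=C(Nc1cccc(-c2nc3ccccc3s2)c1)c1cc([N+](=O)[O-])ccc1Cl`) gives > 27000 nM as a limit. Compound 2 (`O=C(Nc1cc(-c2nc3ccccc3s2)ccc1Cl)c1cc([N+](=O)[O-])ccc1Cl`) gives > 25000 nM as a limit. None of the three therefore has a measured number, and compound 3 cannot be ranked against the other two.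

Compound 4 (`O=C(Nc1cc(-c2nc3ccccc3s2)ccc1F)c1cc([N+](=O)[O-])ccc1Cl`) carries fluoro in place of methyl on an aromatic carbon, ortho to a large group and para to a 1,3-benzothiazol-2-yl group (fluoro in place of methyl on an aromatic carbon). Within the data shown here, three measured steps bear on this change. The closest is a step that the two limits leave unreadable from compound 2 to compound 3 with methyl in place of chloro on the same carbon. At that carbon, chloro in place of hydrogen gave a step that the two limits leave unreadable from compound 1 to compound 2 and methyl in place of hydrogen gave a step that the two limits leave unreadable from compound 1 to compound 3 in the same assay. None of these steps has a readable size, yet hydrogen, chloro and methyl there have all ended in limits.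

For fluoro, no step beyond the usual scatter is therefore expected in this assay and another limit is the likeliest report. The expected outcome is a step that the limit leaves unreadable from compound 3 to compound 4 in this estimate. For compound 4 an estimated 25000 nM is expected, within a range of 12000 nM to 50000 nM as the likely span.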

Compound 4, half-maximal effective concentration: > 25000 nM
Compound 4: no number, only a limit (the forecaster's own chance of this, stated with the estimate: 75%); the middle value lies on the limit itself.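

In this assay, among these compounds, compound 4 gives > 25000 nM, which is a limit and not a number, and no step to it from compound 1, compound 2 or compound 3 can be read. The compounds shown leave open where any of the four reaches its half-maximal effect, and whether exchanging hydrogen, chloro, methyl or fluoro on that carbon changes it.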